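The source may report more compounds than this note shows. Statements on the series, on what has been measured and on what is new or still open speak of the compounds shown alone.

Of the compounds shown here, three sharing one core have been tested in a functional assay on DU-145 cells (Homo sapiens) for cytotoxicity, read by MTT assay, with a stated time of 2 days; a higher number here means a weaker inhibitor, a lower number a stronger inhibitor. Compound 1 `CN(C)CCCNc1nc(NCc2ccco2)c2ccccc2n1` gives 51000 nM, the highest of the three numbers. Compound 2 `Clc1cccc(N2CCN(CCCCNc3nc(NCc4ccco4)c4ccccc4n3)CC2)c1Cl` gives 3870 nM, and compound 3 `Fc1ccc2nc(NCCCCN3CCN(c4cccc(Cl)c4Cl)CC3)nc(NCc3ccco3)c2c1` gives 670 nM; both lie well below compound 1, beyond the scatter. For the measured compounds named here, the only measured step between close neighbours is a 5.8-fold lower number from compound 2 to compound 3 (0.76 log units; beyond the scatter), a change on an aromatic carbon, not on the chain. Compound 4 `CCCCCNc1nc(NCc2ccco2)c2ccccc2n1` differs from compound 1 in a single place: ethyl in place of dimethylamino on a saturated chain carbon, three bonds along the chain from a nitrogen on an aromatic ring. Going by the values given here, no measured pair shows what this particular exchange does, so the expectation rests on compound 1 alone, with the wide spread of the other two numbers as a reminder of how much the chain region can matter. Among the compounds with values here, because compound 1 stands at 51000 nM and no measured step speaks to this change, compound 4 is expected to show a step of a 1.7-fold lower number from compound 1 to compound 4 (0.23 log units; within the scatter), uncertain in direction. Compound 4 is therefore estimated at 30000 nM, most likely between 8000 nM and 100000 nM.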

Compound 4, half-maximal inhibitory concentration: 11500 nM
The estimate for compound 4 lay 2.6-fold (0.42 log units) above the measured number, within the range that was stated.
By their numbers in this assay, from the lowest: compound 3; then compound 2; then compound 4; then compound 1.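

In this assay, putting ethyl in place of dimethylamino on a saturated chain carbon, three bonds along the chain from a nitrogen on an aromatic ring, gives a 4.4-fold lower number from compound 1 to compound 4 (0.65 log units; beyond the scatter). For the compounds shown here, this is the first measured step on the chain itself, since the only earlier step came from a change on an aromatic carbon, and it shows that this position responds to the exchange and that the dimethylamino group is not required for a measurable number in this assay. Nothing available explains why the number moves this way.

The compounds shown leave open whether the step follows from losing the nitrogen or from some other difference between the two groups. A hydroxyl group, a diethylamino group or a longer chain at this position would help to separate these possibilities.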